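Series notes: from compound 2 to compound 3

The source may report more compounds than this note shows. Statements on the series, on what has been measured and on what is new or still open speak of the compounds shown alone.

The shared core appears in compound 1 `C[C@@H](O)[C@H]1C(=O)N2C(C(=O)O)=C(C(C)(C)C)O[C@H]12` and compound 2 `COC(=O)[C@H](O)[C@H]1C(=O)N2C(C(=O)O)=C(C(C)(C)C)O[C@H]12`. In an ADME assay, in phosphate buffer, at 28 degrees C, at pH 7.0 (on this read-out higher numbers stand for a longer-lived compound and lower numbers for a shorter-lived compound), compound 1 gives 8.1 h and compound 2 gives 6.7 h; compound 2 stands at the lower end of the two numbers, though the pair lies within the scatter of one another. Among the compounds with values here, the single measured step, a 1.2-fold lower number from compound 1 to compound 2 (0.08 log units; within the scatter), is within the scatter. Compound 3 `C[C@H](F)[C@H]1C(=O)N2C(C(=O)O)=C(C(C)(C)C)O[C@H]12` carries 1-fluoroethyl in place of hydroxy(methoxycarbonyl)methyl on a saturated ring carbon. Within the data shown here, no measured step matches this exchange directly; the step from compound 1 to compound 2 altered the same saturated ring carbon without a change beyond the scatter, and compound 3 returns to a two-carbon group as in compound 1. No step beyond the scatter is therefore expected in this assay, a 1.1-fold higher number from compound 2 to compound 3 (0.05 log units; within the scatter). Compound 3 is estimated at 7.5 h in this assay, with a range of 3.5 h to 16 h.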

Compound 3, half-life: 7.2 h
Estimate against measurement, compound 3: 1.0-fold (0.02 log units) above, and the stated range covers the measured number.
By their numbers in this assay, from the lowest: compounds 2, 3 and 1 (each within the scatter of the next).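

In this assay the exchange of hydroxy(methoxycarbonyl)methyl for 1-fluoroethyl gives a 1.1-fold higher number from compound 2 to compound 3 (0.03 log units; within the scatter), and the exchange of 1-hydroxyethyl for 1-fluoroethyl gives a 1.1-fold lower number from compound 1 to compound 3 (0.05 log units; within the scatter). The earlier step changed one hydroxy-bearing group for another, whereas these steps show that a group with 0 hydrogen-bond donors and 0 hydrogen-bond acceptors on this saturated ring carbon also stays within the scatter of both hydroxy-bearing groups. No supporting data bear on this result.

Going by these compounds, whether an amine, a carboxylic acid or a longer chain on this saturated ring carbon would shift the half-life beyond the scatter remains open. The compounds shown also leave open whether any change at another place on the shared core would do so.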